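The source may report more compounds than this note shows. Statements on the series, on what has been measured and on what is new or still open speak of the compounds shown alone.

Measured compounds:

Compound 1, `COc1cc(N2C(=O)CC2c2ccc(SC)cc2)cc(OC)c1OC`, gives 67 nM in a functional assay on MCF7 cells (Homo sapiens) for inhibition, read by resazurin assay, with a stated time of 72 h; on this read-out higher numbers stand for weaker inhibition and lower numbers for stronger inhibition.
Compound 2, `C=CC1C(=O)N(c2cc(OC)c(OC)c(OC)c2)C1c1ccc(SC)cc1`, gives 51 nM in this assay.
Compound 3, `CCSc1ccc(C2CC(=O)N2c2cc(OC)c(OC)c(OC)c2)cc1`, gives 141 nM in this assay.

Two single changes connect these three compounds. The first is vinyl in place of hydrogen on a saturated ring carbon, and it made a 1.3-fold lower number from compound 1 to compound 2 (0.12 log units; within the scatter). The second is methyl in place of hydrogen on a saturated chain carbon bound to a sulfur, and it made a 2.1-fold higher number from compound 1 to compound 3 (0.32 log units; beyond the scatter); this is also how the core of compound 3 differs from the core of compound 1. Among the three measured compounds, compound 3 carries the highest number.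

Compound 4, `C=CC1C(=O)N(c2cc(OC)c(OC)c(OC)c2)C1c1ccc(SCC)cc1`, has not been measured. It differs from compound 3 by vinyl in place of hydrogen on a saturated ring carbon. Among the compounds with values here, this is the same kind of change as the one from compound 1 to compound 2, but not the same: around the place, the ring atom in compound 3 bears a 4-(ethylsulfanyl)phenyl group (9 heavy atoms), whereas in compound 1 it bears a 4-(methylsulfanyl)phenyl group (8 heavy atoms).

Within the data shown here, the only guide is a 1.3-fold lower number from compound 1 to compound 2 (0.12 log units; within the scatter), a step that stays within the scatter. The same kind of change on compound 3 is expected to behave in much the same way, so a 1.3-fold lower number from compound 3 to compound 4 (0.11 log units; within the scatter) is estimated to be small and within the scatter as well. On that basis, compound 4 is expected to give about 110 nM in this assay, with a likely range from 55 nM to 220 nM.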

Compound 4, half-maximal inhibitory concentration: 181 nM
For compound 4 the middle estimate is 1.6-fold (0.22 log units) below the measured one, and the stated range covers the measured number.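

In this assay vinyl in place of hydrogen on the saturated ring carbon gives a 1.3-fold higher number from compound 3 to compound 4 (0.11 log units; within the scatter) and so stays small on this second core, in keeping with the earlier step: the same change on two cores in this assay, a 1.3-fold lower number (0.12 log units; within the scatter) from compound 1 to compound 2 and a 1.3-fold higher number (0.11 log units; within the scatter) from compound 3 to compound 4, 1.7-fold (0.23 log units) apart, within the scatter of two such steps.
Methyl in place of hydrogen on the saturated chain carbon bound to a sulfur gives a 3.5-fold higher number from compound 2 to compound 4 (0.55 log units; beyond the scatter) on the core that carries the vinyl group, and this step also agrees with its earlier counterpart: the same change on two cores in this assay, a 2.1-fold higher number (0.32 log units; beyond the scatter) from compound 1 to compound 3 and a 3.5-fold higher number (0.55 log units; beyond the scatter) from compound 2 to compound 4, 1.7-fold (0.23 log units) apart, within the scatter of two such steps.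
Across these four compounds, then, each change behaves on one core much as it does on the other, and the vinyl group makes no clear difference to the number, but two cores are too few to show that either change would carry over in the same way to any further core.

The compounds shown leave open whether a different group on that ring carbon, such as ethyl or hydroxymethyl, would also leave the number about where it stands. They also leave open whether a longer chain on the sulfur, such as propyl, would push the number up further, and what an amine in place of the sulfur would do.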